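Chain extension in a small cell-growth series: compound 4

This account rests on a few compounds, and the source may have more. Where it says the series, first, only, none or still open, it means among the compounds named here.

Of the compounds shown here, three have been measured in a functional assay on PANC-1 cells (Homo sapiens) for inhibition, read by MTT assay, with a stated time of 24 h, tested at 10 uM; a lower number here means less inhibition, a higher number more inhibition at the concentration tested (going by the name of the read-out). Compound 1 `CC(C)=CCOc1cc(=O)n(CCCO)c2c1CC(CC=C(C)C)C(C)(C)C2` gives 20.7%. Compound 3 `CC(C)=CCC/C(C)=C/CC1Cc2c(OCC=C(C)C)cc(=O)n(CCCO)c2CC1(C)C` carries one change relative to compound 1, namely (3-methylbut-2-en-1-yl in place of hydrogen on a saturated chain carbon bound to a double-bonded chain carbon), and the step is a number 9.6 percentage points higher from compound 1 to compound 3 (within the scatter). Compound 2 `CC(C)=CCC1Cc2c(OCCCNS(=O)(=O)c3ccc(C(F)(F)F)cc3)cc(=O)n(CCCO)c2CC1(C)C` gives 29.6% in this assay; the difference between the core of compound 2 and the core of compound 1 is not broken down here. In this assay compound 3 gives 30.3%, which lies within the scatter of the value of compound 2, so no order between the two is claimed.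

Compound 4 `CC(C)=CCC/C(C)=C/CC1Cc2c(OCCCNS(=O)(=O)c3ccc(C(F)(F)F)cc3)cc(=O)n(CCCO)c2CC1(C)C` is not yet measured. It differs from compound 2 by 3-methylbut-2-en-1-yl in place of hydrogen on a saturated chain carbon bound to a double-bonded chain carbon, the same change as that from compound 1 to compound 3, at a place described in the same words. Going by the values given here, only one measured instance of this change exists, and it lies within the scatter. Among the compounds with values here, for compound 4 the expected step is a number 7.4 percentage points higher from compound 2 to compound 4 (within the scatter), because the single precedent a number 9.6 percentage points higher from compound 1 to compound 3 (within the scatter) was of about that size. Compound 4 is therefore expected to give 37%, within a range from 23% to 51%.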

Compound 4, a percentage reported as inhibition, at one concentration (the size of the read-out at that concentration, not a potency): 26.4%
Estimate against measurement, compound 4: 10.6 percentage points above; measured number inside the range.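

In this assay, the new instance of this change on the core of compound 2 is a number 3.2 percentage points lower from compound 2 to compound 4 (within the scatter). Set beside the earlier instance, the two steps do not differ by more than repeated measurements allow: the same change on two cores in this assay, a number 9.6 percentage points higher (within the scatter) from compound 1 to compound 3 and a number 3.2 percentage points lower (within the scatter) from compound 2 to compound 4, 12.8 percentage points apart, within the scatter of two such steps

Neither step stands clear of the scatter, so the two cores give no evidence that the outcome of this change depends on the core, and equally none that the change has a real effect that carries from one core to the other. Two instances, each read at a single concentration, support no rule for this series in either direction.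

On these data alone, it remains open whether an amine or a carboxylic acid in place of the 3-methylbut-2-en-1-yl group, or a chain longer than 3,7-dimethylocta-2,6-dien-1-yl, would give a step beyond the scatter on either core. Potency also remains open, as the read-out gives the size of the inhibition at one concentration only.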